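Amine variation on the shared core: compound 3

The source may hold more compounds than are shown below. What is called first, only, known or untested is meant among the compounds shown, and "the series" means these compounds.

Compound 1 `COCc1cc(OC)c(-c2nc3c(C)ccc(N(C)C)c3cc2C)c(OC)c1` and compound 2 `COCc1cc(OC)c(-c2nc3c(C)ccc(N(CC4CC4)C4CCOCC4)c3cc2C)c(OC)c1` share a core and differ only in the amino group on an aromatic carbon. In an assay on HEK293 cells for displacement of a labelled ligand from corticotropin-releasing factor receptor 1 (Homo sapiens), with a stated time of 2 h (on this read-out lower numbers stand for stronger inhibition and higher numbers for weaker inhibition), compound 1 gives 212 nM and compound 2 gives 246 nM. Compound 2 holds the higher of the two numbers, but the nearest value, that of compound 1, lies within the scatter, so no order between them is claimed. The step of a 1.2-fold higher number from compound 1 to compound 2 (0.06 log units; within the scatter) shows that replacing dimethylamino with the bulkier ring-bearing amine left this assay essentially unchanged.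

Compound 3 `CCC(CC)Nc1ccc(C)c2nc(-c3c(OC)cc(COC)cc3OC)c(C)cc12` is to be measured in this assay. Its change from compound 2 is (pentan-3-yl)amino in place of (cyclopropylmethyl)(oxan-4-yl)amino on an aromatic carbon. Going by the values given here, the only measured step that bears on this position is a 1.2-fold higher number from compound 1 to compound 2 (0.06 log units; within the scatter), and it was flat; no step with a secondary amine or a hydrogen-bond donor at this carbon has been measured. On that basis a step within the scatter is expected, a 1.2-fold lower number from compound 2 to compound 3 (0.09 log units; within the scatter), with no direction favoured. For compound 3 the expected value in this assay is therefore 200 nM, with a range of 70 nM to 600 nM.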

Compound 3, half-maximal inhibitory concentration: > 1000 nM
Compound 3 gave a limit, no number; the forecaster's own chance of this, stated with the estimate: 3%; middle value at least 5.0-fold (0.69 log units) from the limit.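

Compound 3 gives a limit and not a number in this assay: the limit of > 1000 nM in this assay, at which 1 of the 3 values shown sits. This carbon therefore does not accept every amine, as the flat step a 1.2-fold higher number from compound 1 to compound 2 (0.06 log units; within the scatter) alone might have suggested: both an at least 4.0-fold higher number from compound 2 to compound 3 (0.60 log units; beyond the scatter) and an at least 4.7-fold higher number from compound 1 to compound 3 (0.67 log units; beyond the scatter) lie beyond the scatter. The heavy-atom count of the amine does not order the three compounds, since (pentan-3-yl)amino has fewer heavy atoms than the (cyclopropylmethyl)(oxan-4-yl)amino it replaces, yet the still smaller dimethylamino of compound 1 stays within the scatter of compound 2, and the change in compound 3 also brings in 1 hydrogen-bond donor and removes both rings.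

Open, going by these compounds, is whether the hydrogen on the nitrogen or the pentan-3-yl chain goes with the step, and methyl(pentan-3-yl)amino at this carbon would separate the two. Also open, on these data alone, are the true size of the step, which a limit cannot give, and whether a plain amino group or (oxan-4-yl)amino would fall with compound 3 or with compound 1 and compound 2.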